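A Fluorine Added to the Fused Ring of Compound 2

The compounds below may be only part of what the source reports. "The series", "measured", "known", "first", "only" and "open" are said of these compounds alone.

Measured so far:
Compound 1, `Cc1ccc(-c2ccc(C)n2-c2ccc(-c3nc4ccccc4s3)cc2)cc1`, gives 3100 nM in a functional assay on MCF7 cells (Homo sapiens) for cytotoxicity, read by MTT assay, with a stated time of 72 h; a higher number here means a weaker inhibitor, a lower number a stronger inhibitor.
Compound 2, `Cc1ccc(-c2ccc(F)cc2)n1-c1ccc(-c2nc3ccccc3s2)cc1`, gives 3180 nM in this assay.
Compound 3, `Cc1ccc(-c2ccc([N+](=O)[O-])cc2)n1-c1ccc(-c2nc3ccccc3s2)cc1`, gives 3110 nM in this assay.

The three numbers sit within the scatter of one another, so compound 2 cannot be told apart from compound 1 or compound 3 on these data. The steps among them are flat: a 1.0-fold higher number from compound 1 to compound 2 (0.01 log units; within the scatter), a 1.0-fold higher number from compound 1 to compound 3 (0.00 log units; within the scatter) and a 1.0-fold lower number from compound 2 to compound 3 (0.01 log units; within the scatter). Each of these steps changes the group on the outer six-membered ring and none of them moves the number.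

Compound 4, `Cc1ccc(-c2ccc(F)cc2)n1-c1ccc(-c2nc3ccc(F)cc3s2)cc1`, is compound 2 with one more change: fluoro in place of hydrogen on an aromatic carbon. For the measured compounds named here, this is the first change on the fused two-ring part of the core, so no measured step touches the same place. What the three steps do show is that single-atom swaps on an aromatic carbon of this series have left this assay unchanged, and the same outcome is expected here, with no step beyond the scatter in either direction: a 1.0-fold higher number from compound 2 to compound 4 (0.00 log units; within the scatter). Compound 4 is therefore estimated at 3200 nM, within a range of 1600 nM to 6400 nM.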

Compound 4, half-maximal inhibitory concentration: 2800 nM
Compound 4: middle estimate off by 1.1-fold (0.06 log units), on the high side; measured number inside the range.
By their numbers in this assay, from the lowest: compounds 4, 1, 3 and 2 (each within the scatter of the next).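

For the compounds shown here, compound 4 carries the first change on the fused two-ring part of the core, with fluoro in place of hydrogen on an aromatic carbon of a six-membered aromatic ring of carbon only, and it gives a 1.1-fold lower number from compound 2 to compound 4 (0.06 log units; within the scatter) in this assay. The earlier steps shown here spoke only to the group on the outer six-membered ring, whereas this one shows that a single fluoro at this place, meta to a fused ring and para to a fused ring, does not set compound 4 apart from compound 2 in this assay. Nothing measured alongside these numbers bears on why this change leaves the read-out flat.

Fluoro is the only group that the compounds shown place on this ring, so it remains open whether a methoxy group, an amine or a carboxylic acid on the same carbon would give a step beyond the scatter. Also open, from the compounds shown here alone, is whether fluoro on the other carbons of this ring would behave as it does here, and whether this fluoro would stay as flat alongside the nitro group of compound 3.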